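The source may hold more compounds than are shown below. What is called first, only, known or untested is meant among the compounds shown, and "the series" means these compounds.

Working notes on the series. Compound 1 `CC(C)CCCN(C(=O)[C@@H]1C[C@H]1c1ccccc1)c1ccc(-c2ccccc2)cc1` sits at the limit of a functional assay for agonist activity at G protein-coupled receptor 88 (Homo sapiens), read by HTRF and cAMP accumulation; on this read-out lower numbers stand for an effect already at smaller amounts and higher numbers for an effect only at larger amounts of compound: in this assay compound 1 gives > 100 nM, a limit rather than a number (the limit of > 100 nM in this assay, at which 1 of the 3 values shown sits). Within the data shown here, compound 2 `CC(C)C[C@H](N)CCN(C(=O)[C@@H]1C[C@H]1c1ccccc1)c1ccc(-c2ccccc2)cc1` gives 3 nM in this assay, and the step of an at least 33-fold lower number from compound 1 to compound 2 (1.52 log units; beyond the scatter) is the only measured step in the set. Compound 3 `CC[C@H](C)[C@H](N)CN(C(=O)[C@@H]1C[C@H]1c1cccc(OC)c1)c1ccc(-c2ccccc2)cc1` gives 3000 nM in this assay, the highest of the two numbers shown, far from the value of compound 2.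

Compound 4 `CC[C@H](C)[C@H](N)CN(C(=O)[C@@H]1C[C@H]1c1nc(C)cs1)c1ccc(-c2ccccc2)cc1` differs from compound 3 in one place: 4-methyl-1,3-thiazol-2-yl in place of 3-methoxyphenyl on a saturated ring carbon. Among the measured compounds shown here, no measured step touches this part of the core; the one measured step concerns the chain on the amide-type nitrogen, which compound 3 and compound 4 share unchanged. Nothing in the set therefore tells whether swapping the aryl group on the three-membered ring moves the number in this assay, so no step beyond the scatter is expected in either direction, with wide uncertainty.

Compound 4 is expected to give about 3000 nM in this assay, estimated between 500 nM and 15000 nM, which means an expected step of no change at the digits printed from compound 3 to compound 4 (within the scatter).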

Compound 4, half-maximal effective concentration: 730 nM
Beside the measured number, compound 4's estimate is 4.1-fold (0.61 log units) above it; the measured number falls inside the stated range.
By their numbers in this assay, from the lowest: compound 2; then compound 4; then compound 3.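

In this assay the group on a saturated ring carbon of the three-membered ring proves able to move the read-out: 4-methyl-1,3-thiazol-2-yl in place of 3-methoxyphenyl gives a 4.1-fold lower number from compound 3 to compound 4 (0.61 log units; beyond the scatter) and thereby adds a second measured position to the series. Among these compounds, the only earlier step lay on the chain on the amide-type nitrogen, so this is the first evidence from the set that a change at the other end of the amide counts as well, and that a five-membered aromatic ring with 2 hetero atoms can take the place of a six-membered aromatic ring of carbon only at this position. Nothing given here measures a property of either group that would account for the step.

On these data alone, what remains open is which part of the change carries the step, since the ring and its substituent change together; a 1,3-thiazol-2-yl without the methyl group, or a pyridin-2-yl, would separate the two. Also open, as far as these compounds go, is whether the same swap gives a step of similar size on the 1-amino-3-methylbutyl chain of compound 2.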